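A few compounds are considered here, and "the series" means these few. Any claim that something is new, unique, unknown or untested is made for them only; others in the source may bear on it.

Measured so far:
compound 1 `Cn1cncc1C(OCc1ccc(C#N)cc1-c1ccccc1)c1ccc(C#N)cc1` — 140 nM
compound 2 `Cn1cncc1C(OCc1ccc(C#N)cc1C#CC1(O)CCCCC1)c1ccc(C#N)cc1` — 1.93 nM
compound 3 `Cn1cncc1C(OCc1ccc(C#N)cc1C#Cc1cccc(O)c1)c1ccc(C#N)cc1` — > 0.1 nM (a limit)

In a functional assay on NIH3T3 cells (Mus musculus) (a higher number here means that more compound is needed for the effect, a lower number that less compound is needed), compound 1 gives 140 nM, the highest of the two numbers shown. Compound 2 lies well below it: a 73-fold lower number from compound 1 to compound 2 (1.86 log units; beyond the scatter). For compound 3 the assay reports only a limit, > 0.1 nM. The steps a step that the limit leaves unreadable from compound 1 to compound 3 and a step that the limit leaves unreadable from compound 2 to compound 3 therefore cannot be sized; this rests on (the limit of > 0.1 nM in this assay, at which 1 of the 3 values shown sits).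

Compound 4 `Cn1cncc1C(OCc1ccc(C#N)cc1CCC(C)(C)C)c1ccc(C#N)cc1` differs from compound 1 by 3,3-dimethylbutyl in place of phenyl on an aromatic carbon. Both measured steps from compound 1 replace the phenyl with an ethynyl-linked group carrying a hydroxyl; the 3,3-dimethylbutyl has neither the triple bond nor the hydroxyl, so neither step transfers directly. Within the data shown here, the one readable step, a 73-fold lower number from compound 1 to compound 2 (1.86 log units; beyond the scatter), shows that this phenyl can be exchanged with a move to lower numbers, so a modest lowering is expected for compound 4, a 2.8-fold lower number from compound 1 to compound 4 (0.45 log units; beyond the scatter). Compound 4 is estimated at 50 nM, with a range from 10 nM to 300 nM.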

Compound 4, half-maximal effective concentration: 0.54 nM
Estimate against measurement, compound 4: 93-fold (1.97 log units) above; measured number below the stated range.
By their numbers in this assay, from the lowest: compound 4; then compound 2; then compound 1.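

In this assay the step of a 260-fold lower number from compound 1 to compound 4 (2.41 log units; beyond the scatter) is large and shows that this aromatic carbon, ortho to a large group, does not need an aromatic ring for a low number, since 3,3-dimethylbutyl has no ring. The step of a 3.6-fold lower number from compound 2 to compound 4 (0.55 log units; beyond the scatter) is modest but beyond the scatter, and it shows that neither the triple bond nor the hydroxyl of compound 2 is needed for a low number here. For compound 3 the value > 0.1 nM is a limit, and the steps that involve it cannot be read: the limit of > 0.1 nM in this assay, at which 1 of the 4 values shown sits.

Going by these compounds, whether the low number of compound 4 depends on the branching or on the length of the chain stays open; an unbranched hexyl chain and a shorter ethyl group would separate the two. Also open, on these data alone, is how an amine or a carboxylic acid at the end of such a chain would read at this position.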